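Moving the methylsulfanyl group around the aromatic ring

The compounds below may be only part of what the source reports. "The series", "measured", "known", "first", "only" and "open" are said of these compounds alone.

Compound 3 `CSc1cccc(CCCCCCC(=O)c2ncc(-c3ccccn3)o2)c1` carries a 3-(methylsulfanyl)phenyl group, and in an assay for inhibition of Fatty-acid amide hydrolase 1 (Rattus norvegicus) (a lower number here means a stronger inhibitor, a higher number a weaker inhibitor), compound 3 gives 4.2 nM, the higher of the two numbers recorded. Compound 1 `COC(=O)c1ccc(CCCCCCC(=O)c2ncc(-c3ccccn3)o2)cc1` gives 1.5 nM in this assay. Compound 2 `O=C(O)c1cccc(CCCCCCC(=O)c2ncc(-c3ccccn3)o2)c1` is recorded only as a limit of this assay, > 600 nM. Within the data shown here, the single measured step, an at least 140-fold lower number from compound 2 to compound 3 (2.15 log units; beyond the scatter), is large, but it exchanges one group for another and does not bear on where a group sits on the ring. Compound 4 `CSc1ccc(CCCCCCC(=O)c2ncc(-c3ccccn3)o2)cc1` differs from compound 3 by 4-(methylsulfanyl)phenyl in place of 3-(methylsulfanyl)phenyl on a saturated chain carbon, six bonds along the chain from a carbonyl carbon. Among the measured compounds shown here, no measured step tests such a shift, so the expectation rests on the absence of evidence for change. Compound 4 is therefore expected to give 3 nM, between 1 nM and 10 nM. The expected step of a 1.4-fold lower number from compound 3 to compound 4 (0.15 log units; within the scatter) would stay within the scatter.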

Compound 4, inhibition constant: 2.5 nM
Compound 4: the middle estimate sits 1.2-fold (0.08 log units) above what was measured, within the range that was stated.
By their numbers in this assay, from the lowest: compounds 1, 4 and 3 (each within the scatter of the next, the first and the last beyond it). At a limit, above all of these: compound 2.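

In this assay, a shift of the methylsulfanyl group on the ring is now tested directly, and a 1.7-fold lower number from compound 3 to compound 4 (0.23 log units; within the scatter) does not tell 3-(methylsulfanyl)phenyl and 4-(methylsulfanyl)phenyl apart. Exchanging methoxycarbonyl for methylsulfanyl on an aromatic carbon also makes no clear difference, with a 1.7-fold higher number from compound 1 to compound 4 (0.22 log units; within the scatter), whereas exchanging the carboxy-bearing ring gives an at least 240-fold lower number from compound 2 to compound 4 (2.38 log units; beyond the scatter). That last step starts from a limit of the assay, not a number: the limit of > 600 nM in this assay, at which 1 of the 4 values shown sits.

The compounds shown leave open whether 4-carboxyphenyl would match the limit seen for compound 2. They also leave open how an amine in place of methylsulfanyl, or a longer chain, would read.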